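The source may report more compounds than this note shows. Statements on the series, on what has been measured and on what is new or still open speak of the compounds shown alone.

Of the compounds shown here, two have so far been tested in an assay on COS-7 cells for inhibition of patatin-like phospholipase domain-containing protein 2 (Mus musculus); a lower number here means a stronger inhibitor, a higher number a weaker inhibitor. Compound 1 `CCOC(=O)c1ccnc(-c2ccc(OCC)cc2)c1` carries an ethyl ester on its core, and in this assay compound 1 gives 80000 nM. Compound 2 `CCOc1ccc(-c2cccc(C(=O)O)c2)cc1` carries a free carboxylic acid on its core instead. For compound 2 this assay reports only a limit, > 200000 nM, so no exact number is known for it. Compound 2 thus stands at the limit of > 200000 nM in this assay, at which 1 of the 2 values shown sits. Its true potency could lie anywhere beyond that boundary, which makes any step that begins at compound 2 hard to size.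

Compound 3 `CCNC(=O)c1cccc(-c2ccc(OCC)cc2)c1` is the next compound to be measured. It arises from compound 2 by a single change, (ethylamino in place of hydroxy on a carbonyl carbon), so the acid becomes an ethylamide. For the measured compounds named here, no measured pair here compares a free acid with an amide, so the expectation rests only on the two numbers known. This change is expected to amount to an at least 3.3-fold lower number from compound 2 to compound 3 (0.52 log units; beyond the scatter), in the direction of a stronger inhibitor, although the starting point being only a limit leaves the size uncertain. Compound 3 is estimated to give 60000 nM, with a likely range from 15000 nM to 200000 nM, and a fair chance that only a limit is reported again.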

Compound 3, half-maximal inhibitory concentration: 90000 nM
Compound 3: middle estimate off by 1.5-fold (0.18 log units), on the low side, and the stated range covers the measured number.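

Replacing hydroxy with ethylamino on the carbonyl carbon, which turns carboxy into ethylcarbamoyl, produces an at least 2.2-fold lower number from compound 2 to compound 3 (0.34 log units; beyond the scatter) in this assay, so this change moves the number towards a stronger inhibitor by more than the usual scatter. Compound 3, at 90000 nM, also gives this place an exact value against which later changes can be sized. The true size of the step remains unknown, because the value for compound 2 is only a limit: the limit of > 200000 nM in this assay, at which 1 of the 3 values shown sits.

As far as these compounds go, it remains open whether the step comes from losing the carboxylic acid or from gaining the ethyl group, a question that a plain unsubstituted amide on the same carbonyl carbon could help to settle. From the compounds shown here alone, it is also open how the number would respond to a different group on the amide nitrogen, such as a methyl group, a longer propyl or butyl chain, or a chain ending in an amine.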